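Swapping Methoxymethyl for Carboxy on a Chemokine Receptor Antagonist

A few compounds are considered here, and "the series" means these few. Any claim that something is new, unique, unknown or untested is made for them only; others in the source may bear on it.

Three compounds that share one core were tested in a functional assay on CEM-CCRF cells for antagonist activity at C-X-C chemokine receptor type 4 (Homo sapiens), read by calcium flux; on this read-out lower numbers stand for stronger inhibition and higher numbers for weaker inhibition. Compound 1 `NCc1ccccc1CN(Cc1nc2ccccc2[nH]1)C1CCCc2cccnc21` gives 28 nM. Compound 2 `NCc1cc(F)ccc1CN(Cc1nc2ccccc2[nH]1)C1CCCc2cccnc21` gives 219 nM, and a 7.8-fold higher number from compound 1 to compound 2 (0.89 log units; beyond the scatter). Compound 3 `COCc1ccc(CN(Cc2nc3ccccc3[nH]2)C2CCCc3cccnc32)c(CN)c1` gives 21 nM, the lowest of the three numbers; its nearest neighbour is compound 1, since a 1.3-fold lower number from compound 1 to compound 3 (0.12 log units; within the scatter), while a 10-fold lower number from compound 2 to compound 3 (1.02 log units; beyond the scatter).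

Compound 4 `NCc1cc(C(=O)O)ccc1CN(Cc1nc2ccccc2[nH]1)C1CCCc2cccnc21` has not yet been measured. It differs from compound 3 in one place: carboxy in place of methoxymethyl on an aromatic carbon. Among the compounds with values here, no measured step introduces a carboxy group, so the steps that bear on it do so only indirectly. At this position a hydrogen and a methoxymethyl give numbers that sit within the scatter of each other, whereas a fluoro gives a clearly higher number, so the outcome here depends on which group is present. Within the data shown here, with no direct precedent, a modest rise in this assay is expected for compound 4, a 2.9-fold higher number from compound 3 to compound 4 (0.46 log units; beyond the scatter). Compound 4 is expected to give 60 nM in this assay, within a range from 20 nM to 250 nM.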

Compound 4, half-maximal inhibitory concentration: 126 nM
Beside the measured number, compound 4's estimate is 2.1-fold (0.32 log units) below it; the measured number falls inside the stated range.
By their numbers in this assay, from the lowest: compounds 3 and 1 (each within the scatter of the next); then compounds 4 and 2 (each within the scatter of the next).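

Placing carboxy on this aromatic carbon gives a 6.0-fold higher number from compound 3 to compound 4 (0.78 log units; beyond the scatter) when it replaces methoxymethyl and a 4.5-fold higher number from compound 1 to compound 4 (0.65 log units; beyond the scatter) when it replaces hydrogen, so two groups with the same count of heavy atoms do not behave alike here, and only methoxymethyl stays level with hydrogen. Carboxy and fluoro, though very different groups, give numbers that lie within the scatter of each other, with a 1.7-fold lower number from compound 2 to compound 4 (0.24 log units; within the scatter) on this read-out. Nothing measured on these compounds accounts for the differences between the groups.

A methyl ester or a primary amide at this carbon could show whether the number depends on the hydrogen-bond donor that carboxy brings. A longer ether chain or an amine would show how far the tolerance seen with methoxymethyl extends.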